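The source may hold more compounds than are shown below. What is called first, only, known or untested is meant among the compounds shown, and "the series" means these compounds.

In a functional assay on HCT-116 cells (Homo sapiens) for inhibition, read by MTT assay, with a stated time of 72 h (on this read-out lower numbers stand for stronger inhibition of growth and higher numbers for weaker inhibition of growth), compound 1 (`COc1ccc(-c2nc3c(N4CCN(Cc5cc(C)on5)CC4)c(Br)cnc3[nH]2)cc1`) reaches 540 nM and compound 2 (`Cc1cc(CN2CCN(c3c(Cl)cnc4[nH]c(-c5ccc(CN)cc5)nc34)CC2)no1`) reaches 650 nM on the same read-out, so compound 2 stands within the scatter of compound 1. Compound 3 (`Cc1cc(CN2CCN(c3c(Cl)cnc4[nH]c(N5CCN(C)CC5)nc34)CC2)no1`) has not yet been measured. The change (4-methylpiperazin-1-yl in place of 4-(aminomethyl)phenyl on an aromatic carbon) puts 4-methylpiperazin-1-yl in place of 4-(aminomethyl)phenyl on an aromatic carbon of compound 2. Within the data shown here, no measured pair shows a step at this place, so the expectation rests on the structural change alone. In this assay a moderate step towards weaker inhibition of growth, beyond the scatter, is expected, with compound 2 at 650 nM as the starting point. The estimated step (a 3.1-fold higher number from compound 2 to compound 3 (0.49 log units; beyond the scatter)) has that size and direction. For compound 3 the estimated value is 2000 nM with an expected range from 600 nM to 7000 nM in the coming measurement.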

Compound 3, concentration for 50% growth inhibition: 140 nM
For compound 3 the middle estimate is 14-fold (1.15 log units) above the measured one, and the stated range ends above it.
By their numbers in this assay, from the lowest: compound 3; then compounds 1 and 2 (each within the scatter of the next).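

Replacing 4-(aminomethyl)phenyl with 4-methylpiperazin-1-yl on the aromatic carbon between two ring nitrogen atoms gives a 4.6-fold lower number from compound 2 to compound 3 (0.67 log units; beyond the scatter) in this assay, the first step seen at this place. The pair shows that neither the six-membered aromatic ring of carbon nor the hydrogen-bond donor of the group that leaves is required here for inhibition of growth, and that a non-aromatic ring with 2 hetero atoms gives stronger inhibition on this read-out. No measurement at hand explains the size or direction of this step.

The compounds shown leave open whether the ring itself or its methyl group carries the change. An unsubstituted piperazine, a piperazine bearing an ethyl chain or a morpholine at this place would separate these possibilities.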